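The compounds below may be only part of what the source reports. "The series", "measured", "known", "first", "only" and "open" are said of these compounds alone.

Of the compounds shown here, three have so far been tested in an ADME assay on J774.A1 cells (Mus musculus) for cytotoxicity, read by MTT assay, with a stated time of 48 h; a higher number here means that more compound is tolerated, a lower number that less compound is tolerated. Compound 1 `COc1cccc(CNC(=O)c2c([N+](=O)[O-])noc2-c2ccc(Cl)cc2)c1` gives 68600 nM in this assay. Compound 2 `COc1cccc(CNC(=O)c2c([N+](=O)[O-])noc2-c2ccc(Cl)cc2Cl)c1` differs from compound 1 in one place: chloro in place of hydrogen on an aromatic carbon. In this assay compound 2 gives 61200 nM, and the step is a 1.1-fold lower number from compound 1 to compound 2 (0.05 log units; within the scatter). Compound 3 `COC(=O)c1c(NCc2ccccc2)noc1-c1ccc(Cl)cc1Cl` is built on a different core; how the core of compound 1 and the core of compound 3 differ is not broken down here. In this assay compound 3 gives 54200 nM, a number that lies within the scatter of both compound 1 and compound 2, so no order can be read among the three.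

Compound 4 `COC(=O)c1c(NCc2ccc(Cl)cc2)noc1-c1ccc(Cl)cc1Cl` has not yet been measured. It differs from compound 3 in one place: chloro in place of hydrogen on an aromatic carbon. Among the measured compounds shown here, this is the same kind of change as the one from compound 1 to compound 2, but the surroundings are not identical: in compound 2 the chloro enters ortho to a large group and meta to a chloro group, whereas in compound 4 it enters para to a large group, on the benzyl part rather than on the aryl group of the core.

For the measured compounds named here, the only measured example of this kind of change left the tolerated concentration essentially unchanged, because the step from compound 1 to compound 2 was a 1.1-fold lower number from compound 1 to compound 2 (0.05 log units; within the scatter). On that basis the expected step from compound 3 to compound 4 is a 1.1-fold lower number from compound 3 to compound 4 (0.04 log units; within the scatter), also within the scatter. The estimate for compound 4 in this assay is 50000 nM, expected to fall between 28000 nM and 90000 nM.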

Compound 4, half-maximal cytotoxic concentration: 176000 nM
Compound 4: middle estimate off by 3.5-fold (0.55 log units), on the low side; the whole stated range lies below it.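

In this assay, putting a chloro on the benzyl group of compound 3, which turns it into 4-chlorobenzyl, gives a 3.2-fold higher number from compound 3 to compound 4 (0.51 log units; beyond the scatter), so more of the compound is tolerated after this change. The same kind of change, chloro in place of hydrogen on an aromatic carbon, therefore does not carry over as one fixed step between these two cores: the same change on two cores in this assay, a 1.1-fold lower number (0.05 log units; within the scatter) from compound 1 to compound 2 and a 3.2-fold higher number (0.51 log units; beyond the scatter) from compound 3 to compound 4, 3.6-fold (0.56 log units) apart, beyond the scatter of two such steps This does not show what sets the two steps apart, since the two pairs differ both in their core and in the ring that takes the chloro, and a single pair on each side cannot separate these two differences or give a rule for any further core.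

The compounds shown leave open whether a bromo, a hydroxyl or an amine at the same place on the benzyl group of compound 3 would raise the number as the chloro does. They also leave open whether a chloro added to the benzyl group on the core of compound 1 would give a step like the one seen on the core of compound 3.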